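Notes on swapping fluoro for isopropoxy in the thioether series

The compounds below may be only part of what the source reports. "The series", "measured", "known", "first", "only" and "open" are said of these compounds alone.

Compound 1 (`COc1ccccc1Sc1c[nH]c2ccc(Cl)cc12`) reads (> 2500 nM), which is a limit and not a number.
Compound 2 (`COc1cc(Sc2c[nH]c3ccc(F)cc23)cc(OC)c1OC`) reads (160 nM).

Both values come from a functional assay on MCF7 cells (Homo sapiens) for inhibition, with a stated time of 48 h; on this read-out lower numbers stand for stronger inhibition and higher numbers for weaker inhibition. Within the data shown here, compound 2 holds the only actual number so far, and the one other value is a limit. Compound 1 sits at that limit (> 2500 nM). Among the measured compounds shown here, no pair of measured compounds differs in a single place, so no measured step is available as a guide.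

The next compound is compound 3 (`COc1cc(Sc2c[nH]c3ccc(OC(C)C)cc23)cc(OC)c1OC`), which carries isopropoxy in place of fluoro on an aromatic carbon. The rest of the structure matches compound 2.

The expectation therefore starts from compound 2 at (160 nM) and rests on the structural change alone. A moderate loss of inhibition is expected in this assay, clearly beyond the usual scatter but not a collapse, and the estimated step is (a 2.8-fold higher number from compound 2 to compound 3 (0.45 log units; beyond the scatter)). A result reported only as a limit remains possible. Compound 3 is expected at (450 nM), within an estimated range of (100 nM to 2000 nM).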

Compound 3, half-maximal inhibitory concentration: 1500 nM
Compound 3: middle estimate off by 3.3-fold (0.52 log units), on the low side; the measured number falls inside the stated range.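

Isopropoxy in place of fluoro gives a 9.4-fold higher number from compound 2 to compound 3 (0.97 log units; beyond the scatter) in this assay, the first single-place step in the series, so this position, on an aromatic carbon meta to a fused ring and para to a fused ring, is not indifferent to what it carries. The change replaces 1 heavy atom with 4 heavy atoms and adds 1 hydrogen-bond acceptor, and this one step does not show which of these differences matters. Compound 3 still reads as an actual number and not as a limit, and the only limit shown is this one: the limit of > 2500 nM in this assay, at which 1 of the 3 values shown sits.

A single step at this position cannot separate the effect of the added heavy atoms from that of the added acceptor. As far as these compounds go, how an amine or a nitrile at this position would read in this assay stays open, as does the reading of a longer alkoxy chain compared with isopropoxy.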